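This account rests on a few compounds, and the source may have more. Where it says the series, first, only, none or still open, it means among the compounds named here.

Compound 1, with the structure `O=C1C2=C(C(=O)c3ncccc31)C1(CS2)NC(=O)N(c2ccc(Cl)cc2)C1=O`, is the strongest of the three measured compounds in a functional assay on ACHN cells (Homo sapiens) for antiproliferative activity, read by MTT assay, with a stated time of 96 h (a lower number here means a stronger inhibitor, a higher number a weaker inhibitor), where compound 1 gives 4 nM. Compound 2, `O=C1C2=C(C(=O)c3ncccc31)C1(CS2)NC(=O)N(c2ccccc2)C1=O`, carries the change hydrogen in place of chloro on an aromatic carbon and gives 21 nM in this assay; the resulting step is a 5.3-fold higher number from compound 1 to compound 2 (0.72 log units; beyond the scatter). Compound 3, `O=C1NN(c2ccc(Cl)cc2)C(=O)C2(CSC3=C2C(=O)c2ncccc2C3=O)N1`, belongs to a different core; how its core differs from that of compound 1 is not broken down here. In this assay compound 3 gives 360 nM. Compound 4, `O=C1NN(c2ccccc2)C(=O)C2(CSC3=C2C(=O)c2ncccc2C3=O)N1`, is not yet measured and differs from compound 3 by hydrogen in place of chloro on an aromatic carbon, the same change that separates compound 1 from compound 2. Resting on that earlier step, compound 4 is expected to come out at 1500 nM, between 500 nM and 5000 nM, which corresponds to an expected step of a 4.2-fold higher number from compound 3 to compound 4 (0.62 log units; beyond the scatter).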

Compound 4, half-maximal inhibitory concentration: 940 nM
Compound 4: the middle estimate sits 1.6-fold (0.20 log units) above what was measured, and the stated range covers the measured number.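

In this assay the swap of 4-chlorophenyl for phenyl gives a 2.6-fold higher number from compound 3 to compound 4 (0.42 log units; beyond the scatter) and so runs in the same direction as on the core of compound 1. The two steps also agree in size as far as repeated measurements can tell: the same change on two cores in this assay, a 5.3-fold higher number (0.72 log units; beyond the scatter) from compound 1 to compound 2 and a 2.6-fold higher number (0.42 log units; beyond the scatter) from compound 3 to compound 4, 2.0-fold (0.30 log units) apart, within the scatter of two such steps. The change therefore carried over between these two cores, but one pair of cores cannot show that it would carry over to any other core, nor why the chloro compounds give the lower numbers.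

Going by these compounds, only chloro and hydrogen appear at this place, so it remains open how a fluoro, methyl or methoxy group there would compare. On these data alone, whether the same step holds in other cell lines also remains open.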